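This account rests on a few compounds, and the source may have more. Where it says the series, first, only, none or still open, it means among the compounds named here.

Among the compounds with values here, in a functional assay on NCI-H1975 cells (Homo sapiens) for inhibition, read by sulforhodamine B assay, with a stated time of 48 h (on this read-out higher numbers stand for weaker inhibition of growth and lower numbers for stronger inhibition of growth), compound 1 `CC(C)c1cc(C(=O)N(C)c2ccc(NC(=O)CCCCCCCC(=O)NO)cc2)c(O)cc1O` gives 400 nM and holds the only actual number so far. Compound 2 `CC(C)c1cc(C(=O)N(c2ccc(NC(=O)CCCCCCC(=O)NO)cc2)C(C)C)c(O)cc1O` reads > 10000 nM as a limit of the assay, not a number. Compound 3 `CC(C)c1cc(C(=O)Nc2ccccc2NC(=O)CCCCCCC(=O)NO)c(O)cc1O` reads > 10000 nM as a limit too.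

Next in line is compound 4 `CC(C)c1cc(C(=O)N(C)c2ccc(NC(=O)CCCCCC(=O)NO)cc2)c(O)cc1O` which has not yet been read. Within the data shown here, its one structural difference from compound 1 is hydroxycarbamoyl in place of 2-(hydroxycarbamoyl)ethyl on a saturated chain carbon, five bonds along the chain from a carbonyl carbon with hydroxycarbamoyl in place of 2-(hydroxycarbamoyl)ethyl on a saturated chain carbon, five bonds along the chain from a carbonyl carbon. Among the measured compounds shown here, no measured pair isolates this change, and the expectation rests only on compound 1 at 400 nM and on the change itself. A step of a 2.5-fold higher number from compound 1 to compound 4 (0.40 log units; beyond the scatter) is expected in this assay toward weaker inhibition of growth, modest in size and only a little beyond the usual scatter. Compound 4 is estimated at 1000 nM with an expected range from 300 nM to 5000 nM on that reasoning.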

Compound 4, concentration for 50% growth inhibition: 690 nM
Estimate against measurement, compound 4: 1.4-fold (0.16 log units) above; measured number inside the range.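

Hydroxycarbamoyl in place of 2-(hydroxycarbamoyl)ethyl on a saturated chain carbon, five bonds along the chain from a carbonyl carbon, gives a 1.7-fold higher number from compound 1 to compound 4 (0.24 log units; within the scatter) in this assay. Within the data shown here, this is the first pair that isolates a single change, and it shows that this change in chain length does not separate the two compounds on this read-out. Compound 2 and compound 3 each remain a limit of the assay and not a number, and no step to either can be read: the limit of > 10000 nM in this assay, at which 2 of the 4 values shown sit.

The compounds shown leave open how a longer chain, or a carboxylic acid in place of hydroxycarbamoyl, would read at this position. Also open, from the compounds shown here alone, is whether the limit reached by compound 2 follows from its chain or from its isopropyl group on the amide nitrogen.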